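The source may report more compounds than this note shows. Statements on the series, on what has been measured and on what is new or still open speak of the compounds shown alone.

Compound 1 `CCCOC1=C(CCC)C(=O)/C(=C(O)/C=C/c2ccccc2)C(=O)C1(CCC)CCC` stands as the lowest of the two numbers recorded so far. In a functional assay on HCT-8 cells (Homo sapiens) for antiproliferative activity, read by sulforhodamine B assay, with a stated time of 3 days (on this read-out lower numbers stand for an effect already at smaller amounts and higher numbers for an effect only at larger amounts of compound), compound 1 gives 2.6 uM, while compound 2 `CCCC1(CC=C(C)C)C(=O)C(C(=O)/C=C/c2ccccc2)=C(O)C(CCC)(CCC)C1=O` gives 6.7 uM, a higher number lying beyond the usual scatter. Compound 3 `CCCC1=C(OCC(C)C)C(CCC)(CCC)C(=O)/C(=C(O)\C=C\c2ccccc2)C1=O` has not yet been measured; it differs from compound 1 by methyl in place of hydrogen on a saturated chain carbon bound to two saturated chain carbons, so the propoxy group becomes isobutoxy. For the measured compounds named here, no pair of measured compounds shows the effect of this change by itself, so only a small step is expected, a 1.3-fold higher number from compound 1 to compound 3 (0.13 log units; within the scatter), possibly none beyond the scatter. Compound 3 is therefore estimated at 3.5 uM, within 1.5 uM to 8 uM.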

Compound 3, concentration for half-maximal effect: 8 uM
The estimate for compound 3 lay 2.3-fold (0.36 log units) below the measured number; low and high end bracket the measured number.
By their numbers in this assay, from the lowest: compound 1; then compounds 2 and 3 (each within the scatter of the next).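

Adding one methyl to turn propoxy into isobutoxy gives a 3.1-fold higher number from compound 1 to compound 3 (0.49 log units; beyond the scatter) in this assay and so shows that this saturated chain carbon is sensitive to even one extra carbon. For the compounds shown here, no earlier pair of compounds could show this, since none isolated a single change. Nothing available explains the rise. As far as these compounds go, whether a shorter ethoxy, a longer butoxy or a chain ending in an amine would give a lower or higher number here stays open. So does whether this methyl step would repeat on another core.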